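Pentyl for Bromo on a Weakly Active Butenolide Triazole

This account rests on a few compounds, and the source may have more. Where it says the series, first, only, none or still open, it means among the compounds named here.

Compound 1, with structure `O=C1O/C(=C\Cn2cc(-c3ccc(Br)cc3)nn2)C(OCc2ccccc2)=C1OCc1ccccc1`, was tested in a functional assay on MCF7 cells (Homo sapiens) for antiproliferative activity, read by MTT assay, with a stated time of 72 h; on this read-out higher numbers stand for weaker inhibition and lower numbers for stronger inhibition. In this assay compound 1 reaches only the limit > 100000 nM, so no number is available for it. Its standing on the numbers shown is therefore fixed only by the limit of > 100000 nM in this assay, at which 1 of the 2 values shown sits, and whatever potency it has lies beyond what the assay resolves. The other measured compound, compound 2 with structure `O=C1O[C@H]([C@@H](O)Cn2cc(-c3cc(C(F)(F)F)cc(C(F)(F)F)c3)nn2)C(OCc2ccccc2)=C1OCc1ccccc1`, gives 45900 nM in this assay; it differs from compound 1 in several places at once, so the two values say only that both sit at the weak end of what was measured.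

Compound 3, with structure `CCCCCc1ccc(-c2cn(C/C=C3\OC(=O)C(OCc4ccccc4)=C3OCc3ccccc3)nn2)cc1`, has not yet been measured. It differs from compound 1 by pentyl in place of bromo on an aromatic carbon. Going by the values given here, with compound 1 known only as a limit, no measured step can anchor the size of this change. Compound 3 is expected at 80000 nM, between 20000 nM and 300000 nM, an estimated step of an at least 1.2-fold lower number from compound 1 to compound 3 (0.09 log units; that floor lies within the scatter) that may well remain a limit again.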

Compound 3, half-maximal inhibitory concentration: > 100000 nM
Compound 3 ended at the assay's limit; the forecaster's own chance of this, stated with the estimate: 50%; at least 1.2-fold (0.09 log units) between middle value and limit.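

In this assay compound 3 gives > 100000 nM, which is a limit of the assay and not a number. Compound 1 also stands at a limit, so no step can be read between compound 1 and compound 3. The compounds shown leave open whether pentyl in place of bromo changes the antiproliferative activity at all.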